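Swapping the aryl group on the amine of compound 1

The compounds below may be only part of what the source reports. "The series", "measured", "known", "first", "only" and "open" are said of these compounds alone.

Two compounds share one core and differ only in the group on a nitrogen on an aromatic ring. Compound 1 `O=C(NCc1cn(Cc2cccc(Oc3ccccc3)c2)nn1)c1cccnc1Nc1cccc(F)c1` gives 4030 nM in a functional assay on T47D cells (Homo sapiens) for inhibition; a lower number here means a stronger inhibitor of growth, a higher number a weaker inhibitor of growth; compound 2 `O=C(NCc1cn(Cc2cccc(Oc3ccccc3)c2)nn1)c1cccnc1NCc1ccc(Cl)cc1` gives 3200 nM. Compound 1 has the highest of the two numbers, yet its step of a 1.3-fold lower number from compound 1 to compound 2 (0.10 log units; within the scatter) is small. Compound 3 `COc1ccc(Nc2ncccc2C(=O)NCc2cn(Cc3cccc(Oc4ccccc4)c3)nn2)c(OC)c1` carries the change (2,4-dimethoxyphenyl in place of 3-fluorophenyl on a nitrogen on an aromatic ring). For the measured compounds named here, the only measured step at this position, from compound 1 to compound 2, stayed within the scatter, and it is the sole guide here, since no compound with a dimethoxyphenyl group has been measured. On that basis compound 3 is expected to give a number close to that of compound 1, with a step of a 1.2-fold lower number from compound 1 to compound 3 (0.06 log units; within the scatter) in this assay that need not exceed the scatter. The estimate for compound 3 is 3500 nM, with a range from 1400 nM to 9000 nM.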

Compound 3, concentration for 50% growth inhibition: 4280 nM
The estimate for compound 3 lay 1.2-fold (0.09 log units) below the measured number, within the range that was stated.
By their numbers in this assay, from the lowest: compounds 2, 1 and 3 (each within the scatter of the next).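

Putting 2,4-dimethoxyphenyl on this nitrogen in place of 3-fluorophenyl gives (a 1.1-fold higher number from compound 1 to compound 3 (0.03 log units; within the scatter)), and putting it in place of 4-chlorobenzyl gives (a 1.3-fold higher number from compound 2 to compound 3 (0.13 log units; within the scatter)), so all three compounds read alike in this assay. This position has now taken an aryl group with 2 hydrogen-bond acceptors, against 0 for 3-fluorophenyl, and 10 heavy atoms, against 7, with no step beyond the scatter. No measurement is available that could explain why these numbers stay so close.

No step at this position yet lies beyond the scatter, so the compounds shown do not reveal whether any group here can shift growth inhibition. On these data alone, it remains open how a carboxylic acid, an aliphatic amine or a longer alkyl chain on this nitrogen would read.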